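Trimethoxyphenyl triazole thioethers: a ketone replaced by an amide

The source may report more compounds than this note shows. Statements on the series, on what has been measured and on what is new or still open speak of the compounds shown alone.

Compound 2 `COc1cc(-c2nnc(SCC(=O)c3ccc(F)c(F)c3)n2N)cc(OC)c1OC` carries a 3,4-difluorophenyl ketone on the thioether side chain. In a functional assay on HepG2 cells (Homo sapiens) for antiproliferative activity, read by MTT assay, with a stated time of 48 h (a higher number here means a weaker inhibitor, a lower number a stronger inhibitor), compound 2 gives only a limit of the assay, > 100000 nM. Compound 1 `COc1cc(-c2nnc(SCC(=O)c3ccc(Cl)cc3)n2N)cc(OC)c1OC`, which differs by a 4-chlorophenyl ketone, likewise gives a limit, > 100000 nM. The step from compound 1 to compound 2 is therefore a step that the two limits leave unreadable from compound 1 to compound 2. Compound 3 `COc1cc(NC(=O)CSc2nnc(-c3cc(OC)c(OC)c(OC)c3)n2N)cc(OC)c1OC`, an amide bearing a trimethoxyphenyl group on the nitrogen, also reaches only a limit, > 100000 nM. All three values sit at the same limit (the limit of > 100000 nM in this assay, at which 3 of the 3 values shown sit).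

Compound 4 `COc1cc(-c2nnc(SCC(=O)NCc3ccc(Cl)cc3)n2N)cc(OC)c1OC` arises from compound 2 by the change ((4-chlorobenzyl)amino in place of 3,4-difluorophenyl on a carbonyl carbon), so the ketone becomes an amide. No measured step can be read in size, and the amide compound 3 sits at the limit as well, so no step beyond the scatter is expected. The step from compound 2 to compound 4 is expected to be a step that the limit leaves unreadable from compound 2 to compound 4, most likely again as a limit. Compound 4 is expected to give about 150000 nM in this assay, within 30000 nM to 600000 nM.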

Compound 4, half-maximal inhibitory concentration: > 100000 nM
Compound 4: no number, only a limit; the forecaster's own chance of this, stated with the estimate: 85%; the middle value is on the limit's open side.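

Compound 4 gives only a limit of the assay, > 100000 nM, so the steps to compound 4 from compound 1 and compound 2 cannot be read in size. The compounds shown leave open how strongly any of these ketones or amides acts in this assay, and whether changing the side chain matters at all.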